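The source may report more compounds than this note shows. Statements on the series, on what has been measured and on what is new or still open speak of the compounds shown alone.

Compound 1 `CC[C@@H](C)[C@H](NC(=O)c1ccc(Oc2nc3ccccc3nc2C)cc1)C(=O)O`: 35700 nM
Compound 2 `COC(=O)CNC(=O)c1ccc(Oc2nc3ccccc3nc2NC(C)(C)C)cc1`: > 50000 nM (a limit, not a number)

Both compounds were tested in a functional assay on MCF7 cells (Homo sapiens) for antiproliferative activity, read by MTT assay, with a stated time of 48 h; on this read-out higher numbers stand for weaker inhibition and lower numbers for stronger inhibition. Compound 2 stands at the limit of > 50000 nM in this assay, at which 1 of the 2 values shown sits. That value is a limit of the assay and not a number.

Compound 3 `CC(C)C[C@H](NC(=O)c1ccc(Oc2nc3ccccc3nc2NC(C)(C)C)cc1)C(=O)O` has not yet been measured. It has 1-carboxy-3-methylbutyl in place of (methoxycarbonyl)methyl on an amide-type nitrogen of compound 2: 1-carboxy-3-methylbutyl in place of (methoxycarbonyl)methyl on an amide-type nitrogen.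

Among the measured compounds shown here, no measured pair shows this change directly, so the size of the step remains uncertain. Compound 1 also bears a carboxy group and gives 35700 nM, so a modest step towards stronger inhibition is expected in this assay. The estimated change is an at least 1.5-fold lower number from compound 2 to compound 3 (0.18 log units; that floor lies within the scatter). For compound 3 the estimate is 33000 nM, with an expected range of 14000 nM to 50000 nM.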

Compound 3, half-maximal inhibitory concentration: 40300 nM
For compound 3 the middle estimate is 1.2-fold (0.09 log units) below the measured one, and the stated range covers the measured number.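

Among the compounds shown here, replacing (methoxycarbonyl)methyl with 1-carboxy-3-methylbutyl on an amide-type nitrogen gives the first step that can be read at this position in this assay: an at least 1.2-fold lower number from compound 2 to compound 3 (0.09 log units; that floor lies within the scatter). Only this floor is known, and because it lies within the scatter, the data do not establish how large the change is. Compound 2 holds a limit and not a number: the limit of > 50000 nM in this assay, at which 1 of the 3 values shown sits.

On these data alone, it remains open whether the carboxylic acid or the longer chain accounts for the step, and a carboxymethyl group or the methyl ester of the longer chain on the same nitrogen would separate the two. As far as these compounds go, how an amine in place of the carboxylic acid would read in this assay also remains open.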